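Sulfonyl in place of vinylcarbonyl on the ring nitrogen

A few compounds are considered here, and "the series" means these few. Any claim that something is new, unique, unknown or untested is made for them only; others in the source may bear on it.

Of the compounds shown here, three sharing one core have been tested in an ADME assay on MT4 cells (Homo sapiens) for cytotoxicity, read by MTT assay; a lower number here means that less compound is tolerated, a higher number that more compound is tolerated. Compound 1 `CCS(=O)(=O)N1CCN(Cc2ccc(Nc3nccc(Oc4c(C)cc(/C=C/C#N)cc4C)n3)cc2)CC1` gives 4600 nM. Compound 2 `C=CC(=O)N1CCN(Cc2ccc(Nc3nccc(Oc4c(C)cc(C#N)cc4C)n3)cc2)CC1` gives 7580 nM. Compound 3 `C=CC(=O)N1CCN(Cc2ccc(Nc3nccc(Oc4c(C)cc(/C=C/C#N)cc4C)n3)cc2)CC1` gives 5210 nM. Of these three numbers compound 3 holds the second highest, with compound 1 nearest and compound 2 furthest, and both steps stay within the scatter: a 1.1-fold higher number from compound 1 to compound 3 (0.05 log units; within the scatter), and a 1.5-fold lower number from compound 2 to compound 3 (0.16 log units; within the scatter).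

Compound 4 `Cc1cc(/C=C/C#N)cc(C)c1Oc1ccnc(Nc2ccc(CN3CCN(S(=O)(=O)C(C)C)CC3)cc2)n1` has not yet been measured. It differs from compound 3 in a single place: isopropylsulfonyl in place of vinylcarbonyl on an amine nitrogen in a ring. For the measured compounds named here, one measured step bears directly on this spot, the exchange at the same ring nitrogen in which ethylsulfonyl gave way to vinylcarbonyl: a 1.1-fold higher number from compound 1 to compound 3 (0.05 log units; within the scatter), a move that stayed within the scatter. Going by the values given here, the change to compound 4 runs the other way, from vinylcarbonyl back to a sulfonyl group, this time isopropylsulfonyl rather than ethylsulfonyl; no measured pair separates these two sulfonyl groups from each other. The expected outcome in this assay is therefore a step no larger than the scatter, a 1.1-fold lower number from compound 3 to compound 4 (0.04 log units; within the scatter). Compound 4 is estimated at 4800 nM, with a range from 2500 nM to 9500 nM.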

Compound 4, half-maximal cytotoxic concentration: 3810 nM
The estimate for compound 4 lay 1.3-fold (0.10 log units) above the measured number; low and high end bracket the measured number.
By their numbers in this assay, from the lowest: compounds 4, 1, 3 and 2 (each within the scatter of the next).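

In this assay the exchange of vinylcarbonyl for isopropylsulfonyl on the ring nitrogen gives a 1.4-fold lower number from compound 3 to compound 4 (0.14 log units; within the scatter) and so stays within the scatter, which means this position has now taken a second sulfonyl group with no clear shift in the tolerated concentration. For the compounds shown here, for the first time two sulfonyl groups can also be compared directly: the one added methyl on the saturated chain carbon bound to the sulfonyl sulfur gives a 1.2-fold lower number from compound 1 to compound 4 (0.08 log units; within the scatter) and leaves ethylsulfonyl and isopropylsulfonyl indistinguishable in this measurement. Nothing measured here offers an explanation for these small steps.

From the compounds shown here alone, all the groups seen on this nitrogen so far are small acyl or sulfonyl groups, so it remains open whether a quite different one, such as a carboxylic acid or a longer chain ending in an amine, would move the number beyond the scatter. Going by these compounds, it is also open whether a sulfonyl group on this nitrogen would behave the same way with the nitrile on the aromatic carbon in place of 2-cyanoethenyl.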